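Ester-to-amide step on a weakly cytotoxic triazole series

The compounds below may be only part of what the source reports. "The series", "measured", "known", "first", "only" and "open" are said of these compounds alone.

Measured compounds:
- Compound 1 `NS(=O)(=O)c1cc(-c2nnc(CN3CCN(c4ccccc4)CC3)o2)c(Cl)cc1SCc1ccccc1`: 295000 nM
- Compound 2 `CCOC(=O)c1cn(Cc2nnc(-c3cc(S(N)(=O)=O)c(SCc4ccccc4)cc3Cl)o2)nn1`: 150000 nM

In a functional assay on MCF7 cells (Homo sapiens) for cytotoxicity, read by MTT assay, with a stated time of 72 h (a higher number here means a weaker inhibitor, a lower number a stronger inhibitor), compound 1 gives 295000 nM, and compound 2 gives 150000 nM. Within the data shown here, the single step between them, a 2.0-fold lower number from compound 1 to compound 2 (0.29 log units; within the scatter), is within the scatter, so the two values cannot be ordered and neither compound can be called the stronger; compound 2 simply sits at one of two numbers that agree with each other.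

Compound 3 `NC(=O)c1cn(Cc2nnc(-c3cc(S(N)(=O)=O)c(SCc4ccccc4)cc3Cl)o2)nn1` differs from compound 2 by amino in place of ethoxy on a carbonyl carbon. Among the measured compounds shown here, no measured step touches this carbonyl position; the only step in hand lies at a different place and was itself within the scatter, so it gives no direction for the present change. With nothing to argue otherwise, the expectation is no step beyond the scatter, no change at the digits printed from compound 2 to compound 3 (within the scatter).

Compound 3 is therefore estimated at 150000 nM in this assay, with a range from 60000 nM to 400000 nM.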

Compound 3, half-maximal inhibitory concentration: 78000 nM
For compound 3 the middle estimate is 1.9-fold (0.28 log units) above the measured one; measured number inside the range.
By their numbers in this assay, from the lowest: compounds 3, 2 and 1 (each within the scatter of the next, the first and the last beyond it).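

At the carbonyl carbon, amino in place of ethoxy gives a 1.9-fold lower number from compound 2 to compound 3 (0.28 log units; within the scatter) in this assay, so this first reading at the position does not separate the carbamoyl from the ethoxycarbonyl group. Further out, 4-carbamoyl-1H-1,2,3-triazol-1-yl in place of 4-phenylpiperazin-1-yl on the saturated chain carbon gives a 3.8-fold lower number from compound 1 to compound 3 (0.58 log units; beyond the scatter), the only step in the series so far that lies beyond the scatter. Nothing in hand accounts for either step.

Open at the carbonyl carbon is whether hydroxy, giving the carboxylic acid, or a methylamino group would stand apart from compound 2 by more than the scatter. Also open, going by these compounds, is whether a morpholine on the saturated chain carbon would read with compound 1 or with compound 3.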